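Swap of the aryl on the fused core: compound 4 from compound 2

A few compounds are considered here, and "the series" means these few. Any claim that something is new, unique, unknown or untested is made for them only; others in the source may bear on it.

Measured so far in a functional assay on HCT-116 cells (Homo sapiens) for inhibition, read by MTT assay, with a stated time of 24 h, tested at 2.5 uM; a higher number here means more inhibition of growth at the concentration tested, a lower number less inhibition of growth:
compound 1 `CS(=O)(=O)c1ccc(-c2cnc3[nH]cc(-c4nnc(-c5ccncc5)o4)c(=O)c3c2)cc1`: 2.64%
compound 2 `CS(=O)(=O)c1ccc(-c2cnc3[nH]cc(-c4nnc(-c5ccc(F)cc5)o4)c(=O)c3c2)cc1`: 10.7%
compound 3 `CS(=O)(=O)c1ccc(-c2cnc3[nH]cc(-c4nnc(-c5ccccn5)o4)c(=O)c3c2)cc1`: 5.37%

Compound 2 holds the highest of the three numbers, but the gaps to compound 3 and compound 1 are both within the scatter, so no ordering among the three can be drawn. The steps run a number 8.1 percentage points higher from compound 1 to compound 2 (within the scatter) and a number 5.3 percentage points lower from compound 2 to compound 3 (within the scatter); each changes only the aryl on the oxadiazole, and none moves the growth inhibition beyond the scatter.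

Compound 4 `O=c1c(-c2nnc(-c3ccc(F)cc3)o2)c[nH]c2ncc(-c3ccncc3)cc12` is not yet measured. It differs from compound 2 at another site: pyridin-4-yl in place of 4-(methylsulfonyl)phenyl on an aromatic carbon. Within the data shown here, no measured pair changes the group at this position, so the measured steps bear on it only indirectly, by showing that varying an aryl elsewhere on this core left this assay flat. All three numbers sit low, and nothing in the series points to a rise or a fall from this exchange; the expected step is therefore a number 2.7 percentage points lower from compound 2 to compound 4 (within the scatter), that is, none beyond the scatter.

On that basis compound 4 is estimated at 8%, with a range from 0% to 22%.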

Compound 4, percent growth inhibition at one concentration: 7.54%
Compound 4: the middle estimate sits 0.5 percentage points above what was measured; the measured number falls inside the stated range.
By their numbers in this assay, from the lowest: compounds 1, 3, 4 and 2 (each within the scatter of the next).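

The position two atoms from the ring nitrogen, held by 4-(methylsulfonyl)phenyl in all three earlier compounds, now has its first reading: in this assay pyridin-4-yl in place of that group gives a number 3.2 percentage points lower from compound 2 to compound 4 (within the scatter) at the one concentration tested. On this single pair, the smaller ring without the methylsulfonyl group stays level with the parent within the scatter, so the flat picture seen for the aryl on the oxadiazole now also holds at a second site on the shared core. No data on hand speak to the reason for this result.

All four numbers sit low in this assay, so this pair cannot show whether the position matters in a series that inhibits growth more strongly, and one exchange between two aromatic rings says little about the position as a whole. As far as these compounds go, whether an open-chain amine, a carboxylic acid or a longer alkyl chain at this position would move the number beyond the scatter stays open, as does the outcome of pairing pyridin-4-yl here with pyridin-2-yl on the oxadiazole.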